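The source may report more compounds than this note shows. Statements on the series, on what has been measured and on what is new or still open speak of the compounds shown alone.

Of the compounds shown here, three from this series have been measured in a physicochemical assay for lipophilicity, read by HPLC, in phosphate buffer, measured as chromatographic lipophilicity, at pH 7.4; on this read-out lower numbers stand for lower lipophilicity and higher numbers for higher lipophilicity. Compound 1 `Cc1cc(C)cc(NC(=O)COc2cc(C)nc3ccc(C)cc23)c1` gives 5.95, compound 2 `COc1ccc2nc(C)cc(OCC(=O)Nc3cc(F)cc(F)c3)c2c1` gives 5.13, and compound 3 `COc1ccc2nc(C)cc(OCC(=O)Nc3cc(OC)c(Cl)cc3OC)c2c1` gives 5.8. Compound 2 therefore stands lowest of the three, with compound 3 beyond the scatter above it and compound 1 further beyond again.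

Compound 4 `COc1ccc2nc(C)cc(OCC(=O)NC3CONC3=O)c2c1` has not yet been measured. It differs from compound 2 in one place: a group of 6 heavy atoms (3 carbon, 1 nitrogen, 2 oxygen; one five-membered non-aromatic ring with 2 hetero atoms) in place of a group of 8 heavy atoms (6 carbon, 2 fluorine; one six-membered aromatic ring of carbon only), on an amide-type nitrogen.

For the measured compounds named here, no measured pair in this set shows a change of this kind, so the size of the step has to be guessed. The expected step is a number 2.53 log units lower from compound 2 to compound 4 (beyond the scatter). Compound 4 is thus estimated at 2.6, between 1.8 and 3.4.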

Compound 4, distribution coefficient: 0.79
The estimate for compound 4 lay 1.81 log units above the measured number, and the stated range ends above it.
By their numbers in this assay, from the lowest: compound 4; then compound 2; then compounds 3 and 1 (each within the scatter of the next).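

For the compounds shown here, compounds 2 and 4 form the first pair here that differs in one place, and this assay gives a number 4.34 log units lower from compound 2 to compound 4 (beyond the scatter) when the 3,5-difluorophenyl on the amide-type nitrogen is replaced. The group on this nitrogen can therefore move the read-out by a large amount while the core stays the same. Nothing measured here explains the size of this step.

The change removes an aromatic ring and brings in a hydrogen-bond donor and acceptors all at once, so a single pair cannot separate these features. Where a plain phenyl or a cyclopentyl ring on this nitrogen would fall remains open.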